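This account rests on a few compounds, and the source may have more. Where it says the series, first, only, none or still open, it means among the compounds named here.

Measured so far:
compound 1, `Cc1ncc([N+](=O)[O-])n1CCOc1ccccc1` — 107 ug/mL
compound 2, `Cc1ncc([N+](=O)[O-])n1CCOc1cccc([N+](=O)[O-])c1` — 108 ug/mL
compound 3, `Cc1ncc([N+](=O)[O-])n1CCOc1ccccc1[N+](=O)[O-]` — 573 ug/mL

These numbers come from a functional assay on A549 cells (Homo sapiens) for cytotoxicity, read by MTT assay, with a stated time of 24 h; a lower number here means a stronger inhibitor, a higher number a weaker inhibitor. Compound 1 holds the lowest of the three; compound 2 lies within the scatter of it (a 1.0-fold higher number from compound 1 to compound 2 (0.00 log units; within the scatter)), while compound 3 sits further off (a 5.4-fold higher number from compound 1 to compound 3 (0.73 log units; beyond the scatter)). Compound 4, `Cc1ncc([N+](=O)[O-])n1CCOc1ccc(C#N)cc1`, differs from compound 1 by cyano in place of hydrogen on an aromatic carbon. Going by the values given here, no measured step puts a cyano onto this ring; the two steps that exist each add a nitro to the same ring and give either no change or a modest weakening. The cyano step is therefore expected to lie near the scatter or a little upward, a 1.3-fold higher number from compound 1 to compound 4 (0.12 log units; within the scatter). Compound 4 is estimated at 140 ug/mL, with a range from 75 ug/mL to 350 ug/mL.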

Compound 4, half-maximal inhibitory concentration: 79.8 ug/mL
For compound 4 the middle estimate is 1.8-fold (0.24 log units) above the measured one, within the range that was stated.
By their numbers in this assay, from the lowest: compounds 4, 1 and 2 (each within the scatter of the next); then compound 3.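

In this assay the step to a cyano on the aromatic carbon para to a large group reads a 1.3-fold lower number from compound 1 to compound 4 (0.13 log units; within the scatter) and so stays within the scatter. Going by these compounds alone, this gives the first reading at this place on the ring and the first group on it other than nitro. No measurement on hand bears on why the number holds here.

Still open, going by these compounds, is whether an amine or a carboxylic acid at this same place would also stay within the scatter. A nitro at this place also remains to be compared with the cyano.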